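The source may hold more compounds than are shown below. What is called first, only, known or untested is meant among the compounds shown, and "the series" means these compounds.

Measured compounds:
compound 1, `COc1ccc(/C=C2\CN(C(=S)SCc3cn(Cc4ccc(F)cc4)nn3)C/C(=C\c3ccc(OC)cc3)C2=O)cc1`, > 100000 nM in a functional assay on MCF7 cells (Homo sapiens) for cytotoxicity, read by MTT assay, with a stated time of 24 h; on this read-out higher numbers stand for weaker inhibition and lower numbers for stronger inhibition
compound 2, `Cc1ccc(/C=C2\CN(Cc3cn(Cc4ccc(F)cc4)nn3)C/C(=C\c3ccc(C)cc3)C2=O)cc1`, 29000 nM
compound 3, `COc1ccc(/C=C2\CN(C(=S)SCc3cn(Cc4cccc(Cl)c4)nn3)C/C(=C\c3ccc(OC)cc3)C2=O)cc1`, 32000 nM

Compound 1 gives only a limit of the assay, (the limit of > 100000 nM in this assay, at which 1 of the 3 values shown sits), and not a number. Compound 3 shares the core of compound 1 and differs from it by the change (3-chlorophenyl in place of 4-fluorophenyl on a saturated chain carbon bound to an aromatic nitrogen); this change gives an at least 3.1-fold lower number from compound 1 to compound 3 (0.49 log units; beyond the scatter). Compound 2 carries a different core; the difference between the two cores is not broken down here. The numbers of compound 2 and compound 3 lie within the usual scatter of each other, so no order between them is claimed.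

Compound 4, `Cc1ccc(/C=C2\CN(Cc3cn(Cc4cccc(Cl)c4)nn3)C/C(=C\c3ccc(C)cc3)C2=O)cc1`, has not yet been measured in this assay. Among the measured compounds shown here, it differs from compound 2 by 3-chlorophenyl in place of 4-fluorophenyl on a saturated chain carbon bound to an aromatic nitrogen, which is the same change as the one from compound 1 to compound 3. Given that change, compound 4 is expected to show a step of a 1.9-fold lower number from compound 2 to compound 4 (0.29 log units; within the scatter), resting on the step of an at least 3.1-fold lower number from compound 1 to compound 3 (0.49 log units; beyond the scatter) seen on the other core, though that earlier step is known only as a bound. Compound 4 is therefore estimated at 15000 nM, within 5000 nM to 45000 nM.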

Compound 4, half-maximal inhibitory concentration: 10000 nM
Compound 4: the middle estimate sits 1.5-fold (0.18 log units) above what was measured, within the range that was stated.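

In this assay, 3-chlorophenyl in place of 4-fluorophenyl gives a 2.9-fold lower number from compound 2 to compound 4 (0.46 log units; beyond the scatter), and the same change also lowers the number on the core of compound 1, so the direction of the step carries over between the two cores shown: the same change on two cores in this assay, an at least 3.1-fold lower number (0.49 log units; beyond the scatter) from compound 1 to compound 3 and a 2.9-fold lower number (0.46 log units; beyond the scatter) from compound 2 to compound 4; the limit leaves it open whether they differ

Compound 1 gives only a limit of the assay, so the size of the step on its core is not fixed: the limit of > 100000 nM in this assay, at which 1 of the 4 values shown sits.

Two pairs on two cores do not establish a rule for the whole series, and they do not show that the change has the same size on both cores.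

The compounds shown carry only 4-fluorophenyl and 3-chlorophenyl at this place, which leaves open how an unsubstituted phenyl, a 3-fluorophenyl or a 4-chlorophenyl would read, and so whether the halogen or its ring position goes with the step. From the compounds shown here alone, every value comes from this assay, so whether the step holds in any other read-out also stays open.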